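The source may hold more compounds than are shown below. What is called first, only, known or untested is meant among the compounds shown, and "the series" means these compounds.

Compound 1, with the structure `CCN(CC)CN1C(=O)/C(=N\c2nc3ccc(C)cc3s2)c2c(Br)cccc21`, was tested in an ADME assay on 184B5 cells (Homo sapiens) for cytotoxicity, read by sulforhodamine B assay, with a stated time of 48 h (on this read-out lower numbers stand for stronger inhibition of growth and higher numbers for weaker inhibition of growth), where compound 1 gives 34300 nM. Two further compounds were measured alongside it. Compound 2, `O=C1C(=O)N(CN2CCCCC2)c2cccc(Br)c21`, gives 85200 nM in this assay, and compound 3, `O=C1C(=O)N(CN2CCCCC2)c2cccc(Cl)c21`, gives 93700 nM. Compound 1 has the lowest of the three numbers, and its gap to compound 2 and to compound 3 lies beyond the usual scatter. Compound 1 and compound 2 differ in more than one place, and how their two cores differ is not broken down here.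

Compound 2 and compound 3 differ in a single place: chloro in place of bromo on an aromatic carbon. That change gave a 1.1-fold higher number from compound 2 to compound 3 (0.04 log units; within the scatter), so within this pair the swap left the number essentially where it was.

Compound 4, `CCN(CC)CN1C(=O)/C(=N\c2nc3ccc(C)cc3s2)c2c(Cl)cccc21`, has not yet been measured. It differs from compound 1 in the same way: chloro in place of bromo on an aromatic carbon. The change sits at the same place as in the pair of compound 2 and compound 3, so the two occurrences can be compared directly. The expectation for compound 4 rests on compound 3 following compound 2 with a 1.1-fold higher number from compound 2 to compound 3 (0.04 log units; within the scatter): the step from compound 1 to compound 4 in this assay is expected to be a 1.1-fold higher number from compound 1 to compound 4 (0.03 log units; within the scatter), small and within the scatter. Compound 4 is therefore estimated to give 37000 nM, with the likely range running from 20000 nM to 70000 nM.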

Compound 4, concentration for 50% growth inhibition: 87800 nM
The estimate for compound 4 lay 2.4-fold (0.38 log units) below the measured number; the whole stated range lies below it.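

In this assay, putting chloro in place of bromo on the aromatic carbon of the core of compound 1 gave a 2.6-fold higher number from compound 1 to compound 4 (0.41 log units; beyond the scatter) and so produced a modest shift, one larger than repeated measurements would normally show. Placed beside the same change on the other core, this step cannot be firmly separated from the earlier one, as a comparison of two steps carries the uncertainty of both: the same change on two cores in this assay, a 1.1-fold higher number (0.04 log units; within the scatter) from compound 2 to compound 3 and a 2.6-fold higher number (0.41 log units; beyond the scatter) from compound 1 to compound 4, 2.3-fold (0.37 log units) apart, within the scatter of two such steps. The pairs therefore do not prove that the core alters the outcome of this change, nor do they show that the change carries over unaltered, and the small step from the first pair proved a poor guide to the size of the second, so two pairs cannot settle the question.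

Going by these compounds, it remains open what a fluoro group, a methyl group, a methoxy group or a plain hydrogen would do on that same aromatic carbon, and whether such groups would separate the two cores more clearly than chloro and bromo do. On these data alone, it also remains open whether the chloro and bromo pair on a third core would give a step closer to the smaller one or to the larger one.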